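Para-chloro on the arylidene of compound 2

A few compounds are considered here, and "the series" means these few. Any claim that something is new, unique, unknown or untested is made for them only; others in the source may bear on it.

Compound 1 `N#C/C(=C\c1ccco1)C(=O)NCc1ccc(Cl)c(Cl)c1` and compound 2 `N#C/C(=C\c1ccccc1)C(=O)NCc1ccc(Cl)c(Cl)c1` share the amide-linked dichlorobenzyl core and differ in the ring on the double-bonded chain carbon. In a functional assay on NCI-H460 cells (Homo sapiens) for inhibition, read by MTT assay, with a stated time of 72 h (a higher number here means a weaker inhibitor of growth, a lower number a stronger inhibitor of growth), compound 1 gives only a limit, > 50000 nM. In this assay, going by the values given here, compound 2 gives 61000 nM, the only number in the set. The step that the limit leaves unreadable from compound 1 to compound 2 cannot be sized because of the limit of > 50000 nM in this assay, at which 1 of the 2 values shown sits. Compound 3 `N#C/C(=C\c1ccc(Cl)cc1)C(=O)NCc1ccc(Cl)c(Cl)c1` differs from compound 2 by chloro in place of hydrogen on an aromatic carbon. No measured step bears on this change; the one step shown is unreadable. Nothing here supports expecting a shift beyond the scatter, so the expected step of a 1.5-fold lower number from compound 2 to compound 3 (0.18 log units; within the scatter) is small, with weak potency retained. Compound 3 is estimated at 40000 nM in this assay, within a range of 12000 nM to 120000 nM, and a limit rather than a number is a real possibility.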

Compound 3, concentration for 50% growth inhibition: 33000 nM
The estimate for compound 3 lay 1.2-fold (0.08 log units) above the measured number, and the stated range covers the measured number.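

In this assay, the series now has its first readable step, a 1.8-fold lower number from compound 2 to compound 3 (0.27 log units; within the scatter), so chloro on the phenyl, para to a large group, is not separated from hydrogen at this position. Against the furan-2-yl of compound 1, 4-chlorophenyl gives only a floor, an at least 1.5-fold lower number from compound 1 to compound 3 (0.18 log units; that floor lies within the scatter), which does not separate the two rings. The step from compound 1 to compound 2 cannot be read, and the comparison with compound 3 stays a floor, because of this limit: the limit of > 50000 nM in this assay, at which 1 of the 3 values shown sits.

Still open, as far as these compounds go, is whether a dimethylamino group or a carboxylic acid at this same place on the phenyl would move the number beyond the scatter. Also open, from the compounds shown here alone, is whether a longer chain between the amide and the dichlorinated ring would do so.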